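The source may report more compounds than this note shows. Statements on the series, on what has been measured and on what is new or still open speak of the compounds shown alone.

Compound 1 `COc1ccccc1CN1CCN(c2ccc(C(=O)NS(=O)(=O)c3ccc(N[C@H](CCN(C)C)CSc4ccccc4)c([N+](=O)[O-])c3)cc2)CC1` in an assay on isolated protein for displacement of a labelled ligand from Apoptosis regulator Bcl-2 (Homo sapiens), read by fluorescence polarization (a higher number here means a weaker inhibitor, a lower number a stronger inhibitor), gives 3.2 nM. Compound 2 `CN(C)CC[C@H](CSc1ccccc1)Nc1ccc(S(=O)(=O)NC(=O)c2ccc(N3CCN(Cc4ccccc4S(C)(=O)=O)CC3)cc2)cc1[N+](=O)[O-]` in this assay gives 4.6 nM. Compound 3 `COc1ccc(-c2ccccc2CN2CCN(c3ccc(C(=O)NS(=O)(=O)c4ccc(N[C@H](CCN(C)C)CSc5ccccc5)c([N+](=O)[O-])c4)cc3)CC2)cc1` in this assay reaches only a limit of the assay, < 1 nM, which is the limit of < 1 nM in this assay, at which 1 of the 3 values shown sits. The change methylsulfonyl in place of methoxy on an aromatic carbon made the step of a 1.4-fold higher number from compound 1 to compound 2 (0.16 log units; within the scatter). The cores of compound 1 and compound 3 differ by 4-methoxyphenyl in place of methoxy on an aromatic carbon, giving an at least 3.2-fold lower number from compound 1 to compound 3 (0.50 log units; beyond the scatter) and, from the methylsulfonyl analogue, an at least 4.6-fold lower number from compound 2 to compound 3 (0.66 log units; beyond the scatter). Compound 4 `CN(C)CC[C@H](CSc1ccccc1)Nc1ccc(S(=O)(=O)NC(=O)c2ccc(N3CCN(Cc4ccccc4-c4ccc(S(C)(=O)=O)cc4)CC3)cc2)cc1[N+](=O)[O-]` differs from compound 3 by methylsulfonyl in place of methoxy on an aromatic carbon; here the group sits para to a large group, whereas in compound 2 it sits ortho to a large group, so this is the same kind of change, not the same one. The step seen between compound 1 and compound 2, a 1.4-fold higher number from compound 1 to compound 2 (0.16 log units; within the scatter), is taken as the guide for this change. For compound 4 in this assay the expected step is a number no lower from compound 3 to compound 4 (the limit leaves the size open). Compound 4 is therefore estimated at 1 nM, between 0.4 nM and 3 nM.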

Compound 4, inhibition constant: < 1 nM
Compound 4: a limit, no number (the forecaster's own chance of this, stated with the estimate: 40%); the middle value lies on the limit itself.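

In this assay compound 4 gives < 1 nM, which is a limit of the assay and not a number. The change from methoxy to methylsulfonyl therefore cannot be read on this core, because both compounds in the pair carry a limit: the limit of < 1 nM in this assay, at which 2 of the 4 values shown sit.

Carrying the change across cores is thus neither supported nor contradicted; it can be read only on the other core, as a 1.4-fold higher number from compound 1 to compound 2 (0.16 log units; within the scatter), while an at least 4.6-fold lower number from compound 2 to compound 4 (0.66 log units; beyond the scatter) and an at least 3.2-fold lower number from compound 1 to compound 4 (0.50 log units; beyond the scatter) reflect the entry of the 4-(methylsulfonyl)phenyl group, a different change.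

As far as these compounds go, it remains open whether compound 3 and compound 4 differ at all in this assay. Also open, from the compounds shown here alone, is whether a carboxylic acid or an amine in the same place, para to a large group, would stay at the limit.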